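The compounds below may be only part of what the source reports. "The series", "measured", "known", "first", "only" and "open" are said of these compounds alone.

In a functional assay on Bel-7402 cells (Homo sapiens) for antiproliferative activity, read by MTT assay, with a stated time of 72 h (on this read-out higher numbers stand for weaker inhibition and lower numbers for stronger inhibition), compound 1 `C=C1C(=O)O[C@H]2[C@H]1CC/C(COC(=O)CCC(=O)OCn1cc(F)c(=O)[nH]c1=O)=C\CC[C@@]1(C)O[C@@H]21` reports > 20000 nM as a limit of the assay and not as a number. Compound 2 `C=C1C(=O)O[C@H]2[C@H]1CC/C(Cn1cc(Cn3cc(F)c(=O)n(Cc4ccc(F)cc4)c3=O)nn1)=C\CC[C@@]1(C)O[C@@H]21` gives 4910 nM and compound 3 `C=C1C(=O)O[C@H]2[C@H]1CC/C(COC(=O)Cn1cc(F)c(=O)n(Cc3ccc(Br)cc3)c1=O)=C\CC[C@@]1(C)O[C@@H]21` gives 2670 nM in this assay as true numbers. These two values lie within the usual scatter of repeated measurements, so compound 3 cannot be told apart from compound 2 on these data.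

Compound 4 `C=C1C(=O)O[C@H]2[C@H]1CC/C(COC(=O)Cn1cc(F)c(=O)n(Cc3ccc(F)cc3F)c1=O)=C\CC[C@@]1(C)O[C@@H]21` has not yet been measured and differs from compound 3 in a single place. The change is 2,4-difluorophenyl in place of 4-bromophenyl on a saturated chain carbon bound to an aromatic nitrogen and it amounts to 2,4-difluorophenyl in place of 4-bromophenyl on a saturated chain carbon bound to an aromatic nitrogen. Among the measured compounds shown here, no two measured compounds differ in just one place, so the data give no direct measure of what such a swap does. The best starting point is compound 3 at 2670 nM as its closest measured relative, and no step beyond the scatter is expected, in either direction. The expected change is a 1.3-fold higher number from compound 3 to compound 4 (0.12 log units; within the scatter) and it carries wide uncertainty. Compound 4 is estimated at 3500 nM with a range from 1200 nM to 10000 nM as its likely span.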

Compound 4, half-maximal inhibitory concentration: 3670 nM
Beside the measured number, compound 4's estimate is 1.0-fold (0.02 log units) below it, within the range that was stated.
By their numbers in this assay, from the lowest: compounds 3, 4 and 2 (each within the scatter of the next). At a limit, above all of these: compound 1.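

In this assay, compounds 3 and 4 form the first pair shown that differs in one place, so the effect of a change at this position can now be read directly: 2,4-difluorophenyl in place of 4-bromophenyl on a saturated chain carbon bound to an aromatic nitrogen gives a 1.4-fold higher number from compound 3 to compound 4 (0.14 log units; within the scatter) and leaves the two compounds indistinguishable. Among the compounds shown here, at this position, then, replacing a single bromine on the phenyl ring with two fluorines, one heavy atom more, produces no step that can be separated from the ordinary spread of repeat measurements, although this is only one pair. Nothing shown bears on why the read-out behaves this way.

On these data alone, both groups compared here are halogen-bearing benzyl groups, so it remains open whether the number would move with something of another kind at this place, such as a benzyl carrying an amine or a carboxylic acid, or a longer chain in place of the benzyl. It is also open whether the same swap would read the same way on the differently linked side chain of compound 2, for which no one-place partner is shown.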